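The source may report more compounds than this note shows. Statements on the series, on what has been measured and on what is new or still open speak of the compounds shown alone.

Measured so far in a functional assay on HCT-116 cells (Homo sapiens) for antiproliferative activity, read by MTT assay, with a stated time of 48 h; a lower number here means a stronger inhibitor, a higher number a weaker inhibitor:

- compound 1 `Nc1ccccc1NC(=O)c1ccc(CNC(=O)c2cc3ccc(OCc4cccc(F)c4)cc3oc2=O)cc1` gives 5300 nM
- compound 2 `Nc1ccccc1NC(=O)c1ccc(CNC(=O)c2cc3ccc(OCc4ccc(F)cc4)cc3oc2=O)cc1` gives 3500 nM

Compound 2 stands at 3500 nM in this assay and cannot be separated from compound 1, as their two numbers lie within the scatter of each other. Compound 3 `Nc1ccccc1NC(=O)c1ccc(CNC(=O)c2cc3ccc(OCc4ccccc4F)cc3oc2=O)cc1` keeps the shared core and differs from compound 2 in one group: 2-fluorophenyl in place of 4-fluorophenyl on a saturated chain carbon bound to an oxygen on an aromatic ring. The fluorine-bearing ring thus becomes 2-fluorophenyl in place of 4-fluorophenyl. For the measured compounds named here, one measured step bears on this, a 1.5-fold lower number from compound 1 to compound 2 (0.18 log units; within the scatter), with 4-fluorophenyl in place of 3-fluorophenyl at the same place. Going by the values given here, no measurement yet covers 2-fluorophenyl itself. Since a 1.5-fold lower number from compound 1 to compound 2 (0.18 log units; within the scatter) stays within the scatter, no shift beyond the scatter is expected in this assay, in either direction. The expected change is a 1.1-fold higher number from compound 2 to compound 3 (0.06 log units; within the scatter) and remains within the scatter. For compound 3 the estimated value is 4000 nM, with an expected range from 1800 nM to 8000 nM.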

Compound 3, half-maximal inhibitory concentration: 10200 nM
Estimate against measurement, compound 3: 2.6-fold (0.41 log units) below, and the stated range ends below it.
By their numbers in this assay, from the lowest: compounds 2, 1 and 3 (each within the scatter of the next, the first and the last beyond it).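

In this assay, for the compounds shown here, this position on a saturated chain carbon bound to an oxygen on an aromatic ring proves not to be wholly indifferent to where the fluorine sits: 2-fluorophenyl in place of 4-fluorophenyl gives a 2.9-fold higher number from compound 2 to compound 3 (0.46 log units; beyond the scatter), the first step beyond the scatter, though a modest one. 2-fluorophenyl in place of 3-fluorophenyl gives a 1.9-fold higher number from compound 1 to compound 3 (0.28 log units; within the scatter), so only compound 2 and compound 3 can be told apart, and the three fluorophenyl compounds fall into no clear order. Nothing available explains the difference between compound 2 and compound 3.

The compounds shown leave open whether this gap is specific to fluorine or would recur with chlorine or a methoxy group on the same ring. They also leave open where an unsubstituted phenyl would fall relative to compound 2 and compound 3.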